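Replacing the aryl group on the ring nitrogen

A few compounds are considered here, and "the series" means these few. Any claim that something is new, unique, unknown or untested is made for them only; others in the source may bear on it.

Compound 2 `CCCc1nc(-c2ccccc2)c(CNCCN2CCN(c3ccccc3C)CC2)o1` stands as the lowest of the two numbers measured in an assay on HEK293 cells for inhibition of Voltage-dependent T-type calcium channel subunit alpha-1G (Homo sapiens), read by fluorescence, tested at 10 uM (a higher number here means more inhibition at the concentration tested (going by the name of the read-out), a lower number less inhibition), giving 51.3%, while compound 1 `CCCc1nc(-c2ccccc2)c(CNCCN2CCN(c3cccc(C(F)(F)F)c3)CC2)o1` gives 56.3%; the step of a number 5 percentage points lower from compound 1 to compound 2 (within the scatter) lies within the scatter. Compound 3 `CCCc1nc(-c2ccccc2)c(CNCCN2CCN(c3ccccn3)CC2)o1` differs from compound 2 by pyridin-2-yl in place of 2-methylphenyl on an amine nitrogen in a ring. Among the compounds with values here, the only step measured at this position, a number 5 percentage points lower from compound 1 to compound 2 (within the scatter), was within the scatter, so no change beyond the scatter is expected here. In this assay compound 3 is therefore estimated at 45%, within 25% to 65%, which means an expected step of a number 6.3 percentage points lower from compound 2 to compound 3 (within the scatter).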

Compound 3, a percentage reported as inhibition, at one concentration (the size of the read-out at that concentration, not a potency): 48.1%
Compound 3: the middle estimate sits 3.1 percentage points below what was measured, within the range that was stated.
By their numbers in this assay, from the lowest: compounds 3, 2 and 1 (each within the scatter of the next).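

In this assay, the place on the ring nitrogen now also carries an aromatic ring with a hetero atom: pyridin-2-yl, with its hydrogen-bond acceptor, gives a number 3.2 percentage points lower from compound 2 to compound 3 (within the scatter), and measured against 3-(trifluoromethyl)phenyl it gives a number 8.2 percentage points lower from compound 1 to compound 3 (within the scatter). Both steps lie within the scatter, so the three aromatic groups cannot be told apart at this place. Going by these compounds, whether a non-aromatic group here, such as cyclohexyl or a simple methyl, would shift the number beyond the scatter stays open. Nothing available accounts for these steps.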